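This account rests on a few compounds, and the source may have more. Where it says the series, first, only, none or still open, it means among the compounds named here.

Measured so far:
compound 1 `COc1ccc(CNCc2c(OC)cc(Oc3cccc(Nc4ccccc4)c3)cc2OC)cc1`: 1910 nM
compound 2 `COc1cc(Oc2cccc(Nc3ccccc3)c2)cc(OC)c1CN(C)C`: > 20000 nM

Both compounds were tested in a functional assay on DLD-1 cells (Homo sapiens) for inhibition, read by MTT assay, with a stated time of 72 h; on this read-out higher numbers stand for weaker inhibition and lower numbers for stronger inhibition. Compound 1 gives a number, 1910 nM. For compound 2 the result is a limit of this assay rather than a number, > 20000 nM. That reading is the limit of > 20000 nM in this assay, at which 1 of the 2 values shown sits, so compound 2 stands at the weak end of what the assay can report.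

Compound 3 `COc1cc(Oc2cccc(Nc3ccccc3)c2)cc(OC)c1CCO` differs from compound 2 in one place: hydroxymethyl in place of dimethylamino on a saturated chain carbon bound to an aromatic carbon. Among the measured compounds shown here, only one measured step touches this place, an at least 10-fold higher number from compound 1 to compound 2 (1.01 log units; beyond the scatter), and it shows that altering the group on that chain carbon can shift the result strongly. Going by these compounds, whether a further change there could regain inhibition is unknown. Compound 3 is therefore expected to stay near the limit, estimated at 25000 nM, within 8000 nM to 80000 nM. That estimate means a step that the limit leaves unreadable from compound 2 to compound 3.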

Compound 3, half-maximal inhibitory concentration: 18100 nM
The estimate for compound 3 lay 1.4-fold (0.14 log units) above the measured number, within the range that was stated.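

With compound 3, a small group on this saturated chain carbon gives a readable number in this assay, yet hydroxymethyl does not recover what (4-methoxybenzyl)amino gives, with a 9.5-fold higher number from compound 1 to compound 3 (0.98 log units; beyond the scatter). Compound 1 therefore remains the strongest of the three, and its steps to both small groups lie beyond the scatter, whether the new group carries nitrogen or oxygen. Hydroxymethyl and dimethylamino cannot be ranked against each other, since an at least 1.1-fold lower number from compound 2 to compound 3 (0.04 log units; that floor lies within the scatter) is only a floor set by a limit of the assay: the limit of > 20000 nM in this assay, at which 1 of the 3 values shown sits.

The compounds shown cannot tell which part of (4-methoxybenzyl)amino accounts for the stronger number in compound 1. Going by these compounds, a benzylamino group without the methoxy, or a carboxylic acid on the same chain carbon, could fall nearer compound 1 or nearer compound 3, and that remains open.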